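Side chain change from compound 3 to compound 4

This account rests on a few compounds, and the source may have more. Where it says the series, first, only, none or still open, it means among the compounds named here.

Values in a functional assay on the whole organism with Mus musculus as the target, in the maximal electroshock model; a higher number here means that more compound is needed for the effect, a lower number that less compound is needed:
- compound 1 `C[C@@H](NCc1ccc(OCc2ccccc2)cc1)C(N)=O`: 17.1 mg/kg
- compound 2 `CNC(=O)[C@H](C)NCc1ccc(OCc2ccccc2)cc1`: 7 mg/kg
- compound 3 `CNC(=O)[C@@H](CO)NCc1ccc(OCc2ccccc2)cc1`: 22.8 mg/kg

In this assay compound 3 gives 22.8 mg/kg, which is level with one neighbour and apart from the other: a 1.3-fold higher number from compound 1 to compound 3 (0.12 log units; within the scatter), whereas a 3.3-fold higher number from compound 2 to compound 3 (0.51 log units; beyond the scatter). The change to compound 4 `CC[C@@H](NCc1ccc(OCc2ccccc2)cc1)C(N)=O` is 1-carbamoylpropyl in place of 2-hydroxy-1-(methylcarbamoyl)ethyl on an amine nitrogen. For the measured compounds named here, no measured step covers the 1-carbamoylpropyl group itself. Compound 4 carries the carbamoyl group of compound 1, the closest measured compound, and the modest gain seen in a 2.4-fold lower number from compound 1 to compound 2 (0.39 log units; beyond the scatter) belongs to the methylcarbamoyl group that compound 4 lacks. The expected result is a 1.4-fold lower number from compound 3 to compound 4 (0.15 log units; within the scatter), so no step beyond the scatter is expected. For compound 4 the estimate is 16 mg/kg, with an expected range of 8 mg/kg to 32 mg/kg.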

Compound 4, dose for half-maximal effect: 7.2 mg/kg
For compound 4 the middle estimate is 2.2-fold (0.35 log units) above the measured one; the whole stated range lies above it.
By their numbers in this assay, from the lowest: compounds 2 and 4 (each within the scatter of the next); then compounds 1 and 3 (each within the scatter of the next).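

In this assay, for the compounds shown here, methyl on the saturated chain carbon moves the primary amide beyond the scatter (a 2.4-fold lower number from compound 1 to compound 4 (0.38 log units; beyond the scatter)), a first step at this position that leaves the carbamoyl group unchanged. The 1-carbamoylpropyl group stands level with 1-(methylcarbamoyl)ethyl (a 1.0-fold higher number from compound 2 to compound 4 (0.01 log units; within the scatter)) and clear of 2-hydroxy-1-(methylcarbamoyl)ethyl (a 3.2-fold lower number from compound 3 to compound 4 (0.50 log units; beyond the scatter)). Two different single changes to compound 1 thus reach the same range of numbers.

Still open, on these data alone, is whether a longer chain, such as propyl, on this carbon or methylcarbamoyl combined with the ethyl side chain would lower the number further. Nothing available explains these steps.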